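Fluoro removal on the aryl ring: carry-over to the dimethyl core

A few compounds are considered here, and "the series" means these few. Any claim that something is new, unique, unknown or untested is made for them only; others in the source may bear on it.

Measured so far:
compound 1, `O=C1CCCC2=C1C(c1ccc(F)cc1Cl)N=C(c1cccnc1)N2`, 82800 nM
compound 2, `O=C1CCCC2=C1C(c1ccccc1Cl)N=C(c1cccnc1)N2`, 1120000 nM
compound 3, `CC1(C)CC(=O)C2=C(C1)NC(c1cccnc1)=NC2c1ccc(F)cc1Cl`, 624000 nM

All three numbers come from an ADME assay on HepG2 2.2.15 cells (Homo sapiens) for cytotoxicity; a higher number here means a weaker inhibitor, a lower number a stronger inhibitor. Compound 1 and compound 2 share one core and differ by hydrogen in place of fluoro on an aromatic carbon, and that step reads a 14-fold higher number from compound 1 to compound 2 (1.13 log units; beyond the scatter). Compound 3 sits on a different core; the difference between the two cores is not broken down here, and the numbers alone show compound 3 well apart from compound 1 while close to compound 2.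

Compound 4, `CC1(C)CC(=O)C2=C(C1)NC(c1cccnc1)=NC2c1ccccc1Cl`, has not yet been measured in this assay. It differs from compound 3 by hydrogen in place of fluoro on an aromatic carbon, the same change as between compound 1 and compound 2, at a place described in the same words. Among the measured compounds shown here, the expectation for the step from compound 3 to compound 4 is a 4.8-fold higher number from compound 3 to compound 4 (0.68 log units; beyond the scatter), resting on the one earlier instance, compound 1 to compound 2 with a 14-fold higher number from compound 1 to compound 2 (1.13 log units; beyond the scatter), read as likely to carry over in direction though not necessarily in full size. Compound 4 is therefore estimated at 3000000 nM, with a plausible span from 1000000 nM to 9000000 nM.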

Compound 4, half-maximal inhibitory concentration: 67300 nM
Estimate against measurement, compound 4: 45-fold (1.65 log units) above, outside the stated range (below it).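

In this assay, the change from 2-chloro-4-fluorophenyl to 2-chlorophenyl on the core of compound 3 gives a 9.3-fold lower number from compound 3 to compound 4 (0.97 log units; beyond the scatter). The same change on the core of compound 1 ran the opposite way, so in this series neither the direction nor the size of the step carries from one core to the other: the same change on two cores in this assay, a 14-fold higher number (1.13 log units; beyond the scatter) from compound 1 to compound 2 and a 9.3-fold lower number (0.97 log units; beyond the scatter) from compound 3 to compound 4, 130-fold (2.10 log units) apart, beyond the scatter of two such steps

This rests on a single pair per core; it shows that the outcome of removing the fluoro depends on the core in these four compounds, but it does not show which feature of the cores lies behind the reversal, or how any other change on this aromatic ring would behave.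

The compounds shown leave open whether a methoxy group or a bromo group, placed meta to the chloro group, would also reverse between the two cores. Also open, from the compounds shown here alone, is whether a core carrying a single methyl group would follow compound 1 and compound 2 or compound 3 and compound 4.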